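A few compounds are considered here, and "the series" means these few. Any claim that something is new, unique, unknown or untested is made for them only; others in the source may bear on it.

Measured compounds and their results:

Compound 1 `Fc1ccc(N2N=NCC2c2ccncc2)cc1` gives 239 mg/kg
Compound 2 `FC(F)(F)c1cccc(-n2nncc2-c2ccncc2)c1` gives 68.2 mg/kg
Compound 3 `Clc1ccc(-n2nncc2-c2cccnc2)cc1` gives 65.8 mg/kg

In a functional assay on the whole organism with Mus musculus as the target, in the maximal electroshock model (on this read-out higher numbers stand for an effect only at larger amounts of compound and lower numbers for an effect already at smaller amounts), compound 3 gives 65.8 mg/kg, the lowest of the three numbers shown. Its nearest neighbour is compound 2, which gives 68.2 mg/kg; the gap between these two values lies within the usual scatter, so nothing separates them. Compound 1, which gives 239 mg/kg, stands furthest from compound 3, and this gap lies beyond the scatter.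

Compound 4 `Brc1ccc(-n2nncc2-c2cccnc2)cc1` has not yet been measured in this assay. It is obtained from compound 3 by one change: bromo in place of chloro on an aromatic carbon. Going by the values given here, no step between two measured compounds mirrors this exchange of one halogen for another, so there is no measured precedent to lean on. The step is expected to be small, in either direction, and not to reach beyond the scatter; the estimated change from compound 3 to compound 4 is a 1.1-fold lower number from compound 3 to compound 4 (0.04 log units; within the scatter). Compound 4 is therefore expected to give about 60 mg/kg, with a range from 30 mg/kg to 120 mg/kg.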

Compound 4, dose for half-maximal effect: 87.2 mg/kg
Beside the measured number, compound 4's estimate is 1.5-fold (0.16 log units) below it, within the range that was stated.
By their numbers in this assay, from the lowest: compounds 3, 2 and 4 (each within the scatter of the next); then compound 1.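

Going by these compounds alone, the exchange of chloro for bromo on an aromatic carbon, para to a large group, gives a 1.3-fold higher number from compound 3 to compound 4 (0.12 log units; within the scatter) in this assay and is the first step in this set between two measured compounds that differ in one place. Within the data shown here, at this place, the read-out therefore does not separate the two halogens, something the earlier compounds, which differ in more than one place, could not show. No measured finding is available to account for this result.

Going by these compounds, it remains open whether a group of another kind at this place, such as a methoxy group, an amine or a carboxylic acid, would leave the read-out as little changed. On these data alone, it is also open whether the same exchange of halogens would behave alike on the core of compound 1.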